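Working notes: from compound 2 to compound 3

The source may hold more compounds than are shown below. What is called first, only, known or untested is meant among the compounds shown, and "the series" means these compounds.

Measured in a functional assay on OVCAR-4 cells (Homo sapiens) for inhibition, read by sulforhodamine B assay, with a stated time of 48 h; a higher number here means that more compound is tolerated, a lower number that less compound is tolerated:
- compound 1 `Cc1ccc(C2=NN(c3ccc(S(C)(=O)=O)cc3)C(=O)CC2)cc1` gives > 100000 nM, a limit
- compound 2 `Cc1cc(O)ccc1C1=NN(c2ccc(S(C)(=O)=O)cc2)C(=O)CC1` gives > 100000 nM, a limit

In this assay compound 2 gives > 100000 nM, which is a limit and not a number. For the measured compounds named here, the series so far shows only (the limit of > 100000 nM in this assay, at which 2 of the 2 values shown sit).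

Compound 3 `CCc1ccc(C2=NN(c3ccc(S(C)(=O)=O)cc3)C(=O)CC2)cc1` carries 4-ethylphenyl in place of 4-hydroxy-2-methylphenyl on a carbon with a double bond to nitrogen, next to the ring nitrogen: 4-ethylphenyl in place of 4-hydroxy-2-methylphenyl on a carbon with a double bond to nitrogen.

Going by the values given here, the only measured step bearing on this change is a step that the two limits leave unreadable from compound 1 to compound 2, and it gives no size to carry over. No numeric value has been seen in this series. No change beyond the scatter is therefore expected in this assay, in either direction.

The expected step is a number no higher from compound 2 to compound 3 (the limit leaves the size open). For compound 3 the estimated value is 100000 nM, with an expected range of 50000 nM to 200000 nM.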

Compound 3, concentration lethal to 50% of the cells: > 100000 nM
Compound 3 gave a limit, no number; the forecaster's own chance of this, stated with the estimate: 85%; the middle value sits exactly at the limit.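

In this assay compound 3 gives > 100000 nM, which is a limit and not a number. The steps linking compound 3 with compound 1 and compound 2 cannot be read. The compounds shown leave open how any of these changes would shift a measured value, because the series still shows only this: the limit of > 100000 nM in this assay, at which 3 of the 3 values shown sit.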